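Nitrophenyl in Place of Methoxyphenyl: An Expected Value

This account rests on a few compounds, and the source may have more. Where it says the series, first, only, none or still open, it means among the compounds named here.

Two measured compounds share one core and differ only in the group attached to the aromatic nitrogen of a five-membered ring with three nitrogens. In a functional assay on HCT-116 cells (Homo sapiens) for antiproliferative activity, read by MTT assay, with a stated time of 48 h (on this read-out lower numbers stand for stronger inhibition and higher numbers for weaker inhibition), compound 1, `COc1cc(/C=C/C(C)=O)ccc1OCc1cn(-c2ccccc2CO)nn1`, reaches only a limit of the assay, > 100000 nM. Compound 2, `COc1cc(/C=C/C(C)=O)ccc1OCc1cn(-c2ccccc2OC)nn1`, gives 25700 nM in this assay. For the measured compounds named here, the single change between them, methoxy in place of hydroxymethyl on an aromatic carbon, brings an at least 3.8-fold lower number from compound 1 to compound 2 (0.59 log units; beyond the scatter). Going by the values given here, compound 2 therefore holds the only true number seen so far; the other entry is a limit, which the limit of > 100000 nM in this assay, at which 1 of the 2 values shown sits, describes.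

Compound 3, `COc1cc(/C=C/C(C)=O)ccc1OCc1cn(-c2ccc([N+](=O)[O-])cc2)nn1`, has not been measured. Its change from compound 2 is 4-nitrophenyl in place of 2-methoxyphenyl on an aromatic nitrogen. Among the compounds with values here, only one measured step bears on it, and that step swapped a small substituent on the attached phenyl rather than exchanging the whole phenyl for another, so it is a loose guide. The expectation is a step of no more than modest size, in either direction. For compound 3 the expected value in this assay is 25000 nM, within a range from 6000 nM to 90000 nM. The expected step is then a 1.0-fold lower number from compound 2 to compound 3 (0.01 log units; within the scatter).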

Compound 3, half-maximal inhibitory concentration: 96300 nM
The estimate for compound 3 lay 3.9-fold (0.59 log units) below the measured number; the measured number lies above the stated range.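

On the aromatic nitrogen, the whole attached phenyl can be exchanged, and in this assay 4-nitrophenyl in place of 2-methoxyphenyl brings a modest step toward weaker inhibition: a 3.7-fold higher number from compound 2 to compound 3 (0.57 log units; beyond the scatter). Since a higher number means weaker inhibition, both neighbours of compound 2 now fall on the weaker side, one through a changed substituent on the phenyl and one through a different substituted phenyl, so among these three compounds the 2-methoxyphenyl group gives the strongest result, even though that result is still a modest one. 4-Nitrophenyl in place of 2-(hydroxymethyl)phenyl on an aromatic nitrogen brings an at least 1.0-fold lower number from compound 1 to compound 3 (0.01 log units; that floor lies within the scatter), and this step gives only a floor, because one end of it is not a true number but a limit: the limit of > 100000 nM in this assay, at which 1 of the 3 values shown sits.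

Still open, from the compounds shown here alone, is whether the higher number of compound 3 goes with the nitro group itself or with where that group sits on the phenyl, and how a phenyl carrying an amine or a carboxylic acid would behave at this same position in this assay. Nothing among the measurements shown gives a reason for the direction or the size of the step from the methoxy-bearing to the nitro-bearing compound.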